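Compound 2 to compound 4: bromo on the phenethyl ring

This account rests on a few compounds, and the source may have more. Where it says the series, first, only, none or still open, it means among the compounds named here.

In a functional assay on KMS-11 cells (Homo sapiens) for antiproliferative activity, read by CellTiter-Glo, with a stated time of 72 h (a higher number here means a weaker inhibitor, a lower number a stronger inhibitor), compound 1 `COc1ccc(C(=O)N(Cc2ccncc2)Cc2cccc(OCC3CCOCC3)c2)cc1` gives 17700 nM and compound 2 `COc1ccc(C(=O)N(Cc2ccncc2)Cc2cccc(OCCc3ccccc3)c2)cc1` gives 16900 nM while compound 3 `COc1ccc(C(=O)N(Cc2ccncc2)Cc2cccc(OCC3CCN(C(=O)OC(C)(C)C)CC3)c2)cc1` gives 5100 nM as its value. Compound 2 holds the second highest of these three numbers. It lies within the scatter of compound 1, and compound 3 lies lower, beyond the scatter.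

The next change leads to compound 4 `COc1ccc(C(=O)N(Cc2ccncc2)Cc2cccc(OCCc3ccc(Br)cc3)c2)cc1` and reads bromo in place of hydrogen on an aromatic carbon in counted terms. Bromo replaces hydrogen on an aromatic carbon, para to a large group, so phenethyl becomes 2-(4-bromophenyl)ethyl.

Among the measured compounds shown here, only one measured step bears on this side chain: a 1.0-fold lower number from compound 1 to compound 2 (0.02 log units; within the scatter) on replacing oxan-4-yl with benzyl. For the measured compounds named here, that swap stays within the scatter, and no measured step shows a bromo. A small step is therefore expected, with no clear direction. The expected outcome is a 1.3-fold lower number from compound 2 to compound 4 (0.11 log units; within the scatter) as estimated here, with no change beyond the scatter foreseen. Compound 4 is estimated at 13000 nM with 5500 nM to 30000 nM as the expected range.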

Compound 4, half-maximal inhibitory concentration: 8400 nM
Compound 4: middle estimate off by 1.5-fold (0.19 log units), on the high side, within the range that was stated.
By their numbers in this assay, from the lowest: compounds 3, 4, 2 and 1 (each within the scatter of the next, the first and the last beyond it).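

In this assay, the step of a 2.0-fold lower number from compound 2 to compound 4 (0.30 log units; within the scatter) is printed as within the scatter, so 2-(4-bromophenyl)ethyl cannot yet be separated from phenethyl on this side chain. Measured against the oxan-4-yl side chain, the same bromo compound does stand apart: the step of a 2.1-fold lower number from compound 1 to compound 4 (0.32 log units; beyond the scatter) is modest but beyond the scatter, which the step to the unsubstituted phenethyl compound was not. No measurement at hand accounts for either step.

As far as these compounds go, it remains open whether chloro, methoxy or an amine on the same aromatic carbon would read like bromo, or whether the bromo step would hold up on repeated measurement. Also open, from the compounds shown here alone, is how 4-bromophenyl would read on a longer chain.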